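The source may hold more compounds than are shown below. What is called first, only, known or untested is meant among the compounds shown, and "the series" means these compounds.

Compounds measured in a functional assay on spleen for antagonist activity at Alpha-1B adrenergic receptor (Rattus norvegicus); on this read-out higher numbers stand for higher potency (the scale is a negative logarithm) and lower numbers for lower potency:
compound 1 `COc1cccc(OC)c1OCCNCCOc1ccccc1OCc1ccccc1` gives 8.3
compound 2 `COc1cccc(OC)c1OCCNCCOc1ccccc1OCc1ccccc1[N+](=O)[O-]` gives 8.56
compound 3 `COc1cccc(OC)c1OCCNCCOc1ccccc1OCc1cccc([N+](=O)[O-])c1` gives 8.74

Compound 3 holds the highest of the three numbers; compound 2 sits at a number 0.18 log units higher from compound 2 to compound 3 (within the scatter) and compound 1 at a number 0.44 log units higher from compound 1 to compound 3 (beyond the scatter), so only the gap to compound 1 is beyond the scatter.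

Compound 4 `COc1ccc(COc2ccccc2OCCNCCOc2c(OC)cccc2OC)cc1` differs from compound 3 by 4-methoxyphenyl in place of 3-nitrophenyl on a saturated chain carbon bound to an oxygen on an aromatic ring. The step of a number 0.44 log units higher from compound 1 to compound 3 (beyond the scatter) shows what the nitro group added; its removal should undo that gain, while a number 0.26 log units higher from compound 1 to compound 2 (within the scatter) suggests ring substitution at this position moves the number only modestly. For the measured compounds named here, no measured step covers a methoxy group here. A small downward step, near the scatter, is therefore expected in this assay: compound 4 is estimated at 8.4, range 7.9 to 8.9, a step of a number 0.34 log units lower from compound 3 to compound 4 (beyond the scatter).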

Compound 4, negative logarithm of the antagonist equilibrium constant: 9.51
Beside the measured number, compound 4's estimate is 1.11 log units below it; measured number outside the range, above it.
By their numbers in this assay, from the lowest: compounds 1, 2 and 3 (each within the scatter of the next, the first and the last beyond it); then compound 4.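

In this assay, the place on a saturated chain carbon bound to an oxygen on an aromatic ring admits a far larger gain than the nitro compounds showed: 4-methoxyphenyl outdoes both nitrophenyl groups (a number 0.77 log units higher from compound 3 to compound 4 (beyond the scatter)) (a number 0.95 log units higher from compound 2 to compound 4 (beyond the scatter)). Against the unsubstituted compound, methoxy gives the largest step of the set (a number 1.21 log units higher from compound 1 to compound 4 (beyond the scatter)). Nothing available explains this gain.

Group and ring place change together between the nitrophenyl compounds and compound 4, so their shares stay unseparated. As far as these compounds go, whether an ethoxy or a hydroxy group would match the methoxy also remains open.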